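The source may report more compounds than this note shows. Statements on the series, on what has been measured and on what is new or still open speak of the compounds shown alone.

Measured compounds in the series:

compound 1, `COC/C1=C/C[C@](C)(CCC=C(C)C)/C=C/[C@@H](OC(=O)C=C(C)C)[C@](C)(OC)/C=C/C1=O`: 4050 nM
compound 2, `CC(=O)O[C@]1(C)/C=C/C(=O)/C(CO)=C\C[C@](C)(CCC=C(C)C)/C=C/[C@H]1OC(=O)C=C(C)C`: 2370 nM
compound 3, `CC(C)=CCC[C@]1(C)/C=C/[C@@H](OC(=O)C=C(C)C)[C@](C)(O)/C=C/C(=O)/C(CCl)=C\C1`: 160 nM

In a functional assay on HL-60 cells (Homo sapiens) for antiproliferative activity, read by MTT assay, with a stated time of 48 h (on this read-out lower numbers stand for stronger inhibition and higher numbers for weaker inhibition), compound 3 gives 160 nM and stands lowest of the three numbers. Its nearest neighbour is compound 2, whose number is higher by a margin beyond the scatter; compound 1 lies further off again, also beyond the scatter. Going by the values given here, no single-point step between measured compounds is available, so these gaps are read only as what the three values show: the compound carrying chloro at the chain carbon gives the lowest number, and the two compounds carrying oxygen-bearing groups at that position give higher ones.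

Compound 4, `CC(C)=CCC[C@]1(C)/C=C/[C@@H](OC(=O)C=C(C)C)[C@](C)(O)/C=C/C(=O)/C(COC(=O)c2ccc([N+](=O)[O-])cc2)=C\C1`, is not yet measured in this assay. It differs from compound 3 in one place:

((4-nitrophenyl)carbonyl)oxy in place of chloro on a saturated chain carbon bound to a double-bonded ring carbon

The step from compound 3 to compound 4 is expected to go upward, in the direction of the numbers shown by compound 1 at 4050 nM and compound 2 at 2370 nM, both of which carry an oxygen-linked group in place of chloro. The size of the expected step is put at a 9.4-fold higher number from compound 3 to compound 4 (0.97 log units; beyond the scatter), beyond the scatter. For compound 4 the estimated value in this assay is 1500 nM, with a range from 400 nM to 6000 nM.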

Compound 4, half-maximal inhibitory concentration: 830 nM
Compound 4: the middle estimate sits 1.8-fold (0.26 log units) above what was measured; the range from low to high includes it.
By their numbers in this assay, from the lowest: compound 3; then compound 4; then compounds 2 and 1 (each within the scatter of the next).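

In this assay, going by these compounds alone, the step gives the first reading of this position with the rest of compound 3 held constant: ((4-nitrophenyl)carbonyl)oxy in place of chloro on a saturated chain carbon bound to a double-bonded ring carbon gives a 5.2-fold higher number from compound 3 to compound 4 (0.71 log units; beyond the scatter). This shows that the change at this position alone moves the number beyond the scatter, which compounds 1 and 2 could not show, as each differs from compound 3 in more than one place; the step is modest, even though 12 heavy atoms, including a six-membered aromatic ring, replace a single chlorine. Nothing available on compound 3 or compound 4 accounts for the direction or size of the step.

Within the data shown here, the single step cannot separate the loss of chloro from the entry of the ester, nor show which part of the entering group matters, so a plain benzoyloxy or acetoxy group at this carbon would be informative. It also leaves open how bromo, fluoro or a dimethylamino group at the same carbon would read against compound 3 at 160 nM.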